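Aromatic methyl to hydrogen: working notes on compound 3

The source may report more compounds than this note shows. Statements on the series, on what has been measured and on what is new or still open speak of the compounds shown alone.

Measured in a functional assay on U-87MG ATCC cells for inhibition, with U-87 MG (Homo sapiens) as the target, read by MTT assay, with a stated time of 72 h; a higher number here means a weaker inhibitor, a lower number a stronger inhibitor:
compound 1 `COc1ccccc1-c1csc2cnc(Nc3ccc(NC(=O)[C@H]4CCCNC4)cc3)nc12`: 300 nM
compound 2 `COc1ccccc1-c1csc2cnc(Nc3ccc(C(=O)NC4CCNCC4)cc3C)nc12`: 250 nM

Compound 2 at 250 nM lies within the usual scatter of compound 1 at 300 nM, so the two numbers set no order in this assay. The next compound to be measured is compound 3 `COc1ccccc1-c1csc2cnc(Nc3ccc(C(=O)NC4CCNCC4)cc3)nc12`, which differs from compound 2 at a single place: hydrogen in place of methyl on an aromatic carbon. It has hydrogen in place of methyl on an aromatic carbon. Within the data shown here, compounds 1 and 2 differ in more than one place, so no measured step isolates this change. The step expected a 1.1-fold lower number from compound 2 to compound 3 (0.06 log units; within the scatter) in this assay lies within the scatter, with no direction favoured. For compound 3 the estimated value is 220 nM, with an expected range of 90 nM to 550 nM.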

Compound 3, half-maximal inhibitory concentration: 650 nM
For compound 3 the middle estimate is 3.0-fold (0.47 log units) below the measured one; measured number above the stated range.
By their numbers in this assay, from the lowest: compounds 2 and 1 (each within the scatter of the next); then compound 3.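

In this assay, among these compounds, the methyl on this aromatic carbon, ortho to a large group and meta to the (piperidin-4-yl)carbamoyl group, is the first single change that can be read, and hydrogen in its place gives a 2.6-fold higher number from compound 2 to compound 3 (0.41 log units; beyond the scatter) so that methyl is favoured over hydrogen here by a modest step. Without the methyl, the (piperidin-4-yl)carbamoyl group also separates from the ((piperidin-3-yl)carbonyl)amino group, with a 2.2-fold higher number from compound 1 to compound 3 (0.34 log units; beyond the scatter) as a modest step, whereas the values of compound 1 and compound 2 set no order. Nothing measured here explains either step.

Going by these compounds, whether this preference is particular to methyl stays open, and a chlorine or an ethyl group on the same carbon would test it. Also open, on these data alone, is whether the same methyl would have a similar effect alongside the ((piperidin-3-yl)carbonyl)amino group of compound 1.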